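This account rests on a few compounds, and the source may have more. Where it says the series, first, only, none or still open, it means among the compounds named here.

Measured compounds:
- compound 1 `C[C@@H](C(=O)O)c1nn(Cc2cn3cc(OCC4CC4)c(Cl)cc3n2)c2ccccc2c1=O`: 182 nM
- compound 2 `O=C(O)Cn1nc(Cc2cn3cc(OCC4CC4)c(Cl)cc3n2)c2ccccc2c1=O`: 7.6 nM
- compound 3 `O=C(O)Cn1nc(Cn2cc3cc(OCC4CC4)c(Cl)cc3n2)c2ccccc2c1=O`: 8.1 nM

These three compounds were tested in a functional assay on HFL1 cells for antagonist activity at sphingosine 1-phosphate receptor 2 (Homo sapiens), read by ELISA, with a stated time of 24 h; on this read-out higher numbers stand for weaker inhibition and lower numbers for stronger inhibition. Compound 1 gives the highest number of the three, 182 nM, and so the weakest inhibition. Compound 2, at 7.6 nM, and compound 3, at 8.1 nM, both sit well below it, and both gaps lie beyond the usual scatter. Compound 2 and compound 3 carry their acid on a different part of the shared core than compound 1 does, so no single change links either of them to compound 1.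

Compound 4 `O=C(O)Cc1nn(Cc2cn3cc(OCC4CC4)c(Cl)cc3n2)c2ccccc2c1=O` has not yet been measured in this assay. It differs from compound 1 in one place: hydrogen in place of methyl on a saturated chain carbon bound to an aromatic carbon and a carbonyl carbon. Because compound 1 stands at 182 nM while the two acids without that methyl, compound 2 and compound 3, sit far lower, some gain in inhibition is expected, though with caution, as the attachment of the acid also differs in those two compounds. The expected step from compound 1 to compound 4 is a 4.0-fold lower number from compound 1 to compound 4 (0.61 log units; beyond the scatter). Compound 4 is therefore estimated at 45 nM, with a range from 8 nM to 250 nM.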

Compound 4, half-maximal inhibitory concentration: 4.8 nM
The estimate for compound 4 lay 9.4-fold (0.97 log units) above the measured number; the whole stated range lies above it.
By their numbers in this assay, from the lowest: compounds 4, 2 and 3 (each within the scatter of the next); then compound 1.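

In this assay, replacing 1-carboxyethyl with carboxymethyl gives a 38-fold lower number from compound 1 to compound 4 (1.58 log units; beyond the scatter), so removing a single carbon atom changes the result by far more than the usual scatter. This is the first pair shown that differs in only one place, so the effect of the methyl on this saturated chain carbon bound to an aromatic carbon and a carbonyl carbon can be read directly, without the change in where the acid is attached that separates compound 1 from the other two compounds measured earlier. The data shown include no measurement that explains why so small a change has so large an effect on the read-out.

The compounds shown leave open whether an ethyl group, a fluorine atom or a hydroxyl group on this carbon would give a number closer to that of compound 1 or to that of compound 4, and whether the methyl in its mirror-image arrangement would give the same step. They also leave open how a longer chain carrying the carboxylic acid would compare with the carboxymethyl group of compound 4.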